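A few compounds are considered here, and "the series" means these few. Any claim that something is new, unique, unknown or untested is made for them only; others in the source may bear on it.

The series shares one core, carried by three measured compounds. Compound 1 `COc1cc(Cl)cc(-c2nn(-c3cccc(NC(=O)Nc4cccc(C(F)(F)F)c4)c3)cc2-c2ccncc2)c1` gives 3.28% in a functional assay on OVCAR-4 cells (Homo sapiens) for inhibition, read by sulforhodamine B assay, with a stated time of 48 h, tested at 10 uM; a lower number here means a stronger effect, a higher number a weaker effect of the compound at the concentration tested. Within the data shown here, compound 2 `COc1cc(Cl)cc(-c2nn(-c3cccc(NC(=O)c4cccc(C(F)(F)F)c4)c3)cc2-c2ccncc2)c1` gives 71.8% in this assay, and the one measured step, a number 68.5 percentage points higher from compound 1 to compound 2 (beyond the scatter), shows how far a single change to the carbonyl carbon can move the read-out. Compound 3 `O=C(Nc1cccc(-n2cc(-c3ccncc3)c(-c3cc(O)cc(Cl)c3)n2)c1)c1cc(C(F)(F)F)cc(C(F)(F)F)c1` gives 59.6% in this assay, which places it second highest of the three, beyond the scatter from compound 2 above it and far beyond the scatter from compound 1 below it.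

Compound 4 `COc1cc(Cl)cc(-c2nn(-c3cccc(NC(=O)c4cc(C(F)(F)F)cc(C(F)(F)F)c4)c3)cc2-c2ccncc2)c1` is not yet measured. Relative to compound 3 the change is methyl in place of hydrogen on an oxygen on an aromatic ring. Among the measured compounds shown here, no measured step in this set exchanges hydroxy for methoxy, so the step from compound 1 to compound 2 bears only indirectly, as a reminder of how wide the spread can be. Compound 2 carries the same methoxy and an amide, and its value sits near that of compound 3.

The step from compound 3 to compound 4 is therefore expected to be a number 5.4 percentage points higher from compound 3 to compound 4 (within the scatter), within the scatter. Compound 4 is expected to give about 65% in this assay, between 45% and 85%.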

Compound 4, a percentage reported as activity, at one concentration (the size of the read-out at that concentration, not a potency): 72.1%
Estimate against measurement, compound 4: 7.1 percentage points below; measured number inside the range.
By their numbers in this assay, from the lowest: compound 1; then compound 3; then compounds 2 and 4 (each within the scatter of the next).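

In this assay, the exchange of hydroxy for methoxy now has a direct reading: a number 12.5 percentage points higher from compound 3 to compound 4 (beyond the scatter) marks a weaker effect at the concentration tested, so this oxygen on the aromatic ring is a place where a single methyl changes the read-out. That step is much smaller than the one seen earlier at the carbonyl carbon, a number 68.5 percentage points higher from compound 1 to compound 2 (beyond the scatter) being of a different order. The added trifluoromethyl on the aromatic carbon does not register, as a number 0.3 percentage points higher from compound 2 to compound 4 (within the scatter) shows, so in this methoxy pair either hydrogen or trifluoromethyl gives the same reading.

On these data alone, how an ethyl group or a longer chain on this oxygen, or an amine in place of the hydroxy, would read remains open. Nothing among the data given explains the shift at this oxygen.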